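The source may hold more compounds than are shown below. What is called first, only, known or untested is meant among the compounds shown, and "the series" means these compounds.

Measured in a functional assay on A549 cells (Homo sapiens) for antiproliferative activity, read by MTT assay, with a stated time of 72 h; a lower number here means a stronger inhibitor, a higher number a weaker inhibitor:
compound 1 `NC1=NC2(CCOCC2)N(OCCCOc2cccc(Cl)c2Cl)C(N)=N1` gives 100 nM
compound 2 `NC1=NC2(CCOCC2)N(OCCCOc2cc(Cl)c(Cl)cc2Cl)C(N)=N1` gives 680 nM
compound 3 `NC1=NC2(CCOCC2)N(OCCCOc2ccccc2Br)C(N)=N1` gives 160 nM

Compound 3 lies within the scatter of its nearest neighbour (a 1.6-fold higher number from compound 1 to compound 3 (0.20 log units; within the scatter)) and clearly under the highest number (a 4.3-fold lower number from compound 2 to compound 3 (0.63 log units; beyond the scatter)). Next is compound 4 `NC1=NC2(CCOCC2)N(OCCCOc2ccc(Br)cc2)C(N)=N1`, with 4-bromophenyl in place of 2-bromophenyl on an oxygen on a saturated carbon. Within the data shown here, no measured step makes this exact change. Among the measured compounds shown here, the closest guide is compound 2, the only measured compound whose group name carries a 4, and it sits higher (a 6.8-fold higher number from compound 1 to compound 2 (0.83 log units; beyond the scatter)). A small upward step is therefore expected, not clearly beyond the scatter. The expected step is a 1.8-fold higher number from compound 3 to compound 4 (0.24 log units; within the scatter) in this assay and remains uncertain. For compound 4 the estimated value is 280 nM, with an expected range of 90 nM to 850 nM.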

Compound 4, half-maximal inhibitory concentration: 280 nM
The estimate for compound 4 equals the measured number at the digits printed; low and high end bracket the measured number.
By their numbers in this assay, from the lowest: compounds 1, 3 and 4 (each within the scatter of the next, the first and the last beyond it); then compound 2.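

Relocating the bromine from 2-bromophenyl to 4-bromophenyl gives the series its first pair with the same atoms joined differently, and this assay does not separate the two: a 1.8-fold higher number from compound 3 to compound 4 (0.24 log units; within the scatter). Steps from the chlorinated aryl groups are beyond the scatter, in opposite directions: a 2.4-fold lower number from compound 2 to compound 4 (0.39 log units; beyond the scatter) and a 2.8-fold higher number from compound 1 to compound 4 (0.45 log units; beyond the scatter). Nothing available explains these differences.

On these data alone, it remains open whether an unsubstituted phenyl or a 4-chlorophenyl group would fall in the same range. A longer chain between the oxygens is also untested here.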